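Cytotoxicity notes on a carbamate-bearing amide series

This account rests on a few compounds, and the source may have more. Where it says the series, first, only, none or still open, it means among the compounds named here.

Measured so far: compound 1 `CC(C)(NC(=O)OCc1ccccc1)c1nc(O)c(O)c(C(=O)N/N=C/c2ccc(F)cc2)n1` gives 378000 nM in an ADME assay on C8166 cells (Homo sapiens) for cytotoxicity, read by MTT assay, with a stated time of 3 days; on this read-out higher numbers stand for lower toxicity in this test and lower numbers for higher toxicity in this test; compound 2 `COCCNC(=O)c1nc(C(C)(C)NC(=O)OCc2ccccc2)nc(O)c1O` gives 348000 nM; compound 3 `COc1cc(CNC(=O)c2nc(C(C)(C)NC(=O)OCc3ccccc3)nc(O)c2O)cc(OC)c1OC` gives 110000 nM.

Compound 3 stands lowest of the three numbers in this assay, with compound 2 nearest and compound 1 furthest. Compound 4 `CC(C)(NC(=O)OCc1ccccc1)c1nc(O)c(O)c(C(=O)NCc2ccccc2)n1` differs from compound 3 by phenyl in place of 3,4,5-trimethoxyphenyl on a saturated chain carbon bound to an amide-type nitrogen. The step bearing on it is a 3.2-fold lower number from compound 2 to compound 3 (0.50 log units; beyond the scatter), a modest move; the step of a 1.1-fold lower number from compound 1 to compound 2 (0.04 log units; within the scatter) was within the scatter. Removing the three methoxy groups is expected to return the number partway toward compounds 1 and 2, so for compound 4 a step of a 2.1-fold higher number from compound 3 to compound 4 (0.32 log units; beyond the scatter) is estimated. Compound 4 is therefore expected near 230000 nM, with a range from 110000 nM to 480000 nM.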

Compound 4, half-maximal cytotoxic concentration: 41400 nM
The estimate for compound 4 lay 5.6-fold (0.74 log units) above the measured number, and the stated range ends above it.
By their numbers in this assay, from the lowest: compound 4; then compound 3; then compounds 2 and 1 (each within the scatter of the next).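

In this assay, the unsubstituted phenyl gives the lowest number at this place, with a 2.7-fold lower number from compound 3 to compound 4 (0.42 log units; beyond the scatter), so the three methoxy groups go with a higher number here, not a lower one. The ring alone, without those groups, gives a far larger step than the trimethoxyphenyl did, with an 8.4-fold lower number from compound 2 to compound 4 (0.92 log units; beyond the scatter) and a 9.1-fold lower number from compound 1 to compound 4 (0.96 log units; beyond the scatter). No measurement available explains this order.

As far as these compounds go, whether a single methoxy on the phenyl already raises the number remains open. So does the outcome with a pyridyl ring or a carboxylic acid at this place.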